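A Larger Ring on a Compound Already at the Limit

The source may hold more compounds than are shown below. What is called first, only, known or untested is meant among the compounds shown, and "the series" means these compounds.

Of the compounds shown here, three sharing one core have been tested in an in vitro ADME assay on microsomes from liver (Homo sapiens) for metabolic stability, tested at 5 uM; on this read-out higher numbers stand for a longer-lived compound and lower numbers for a shorter-lived compound. Compound 1 `CS(=O)(=O)Nc1ccc2c(c1)S(=O)(=O)N=C(c1c(O)c(-c3cccs3)nn(CCC3CC3)c1=O)N2` gives > 1 h, which is a limit and not a number. Compound 2 `CCC(C)n1nc(-c2cccs2)c(O)c(C2=NS(=O)(=O)c3cc(NS(C)(=O)=O)ccc3N2)c1=O` gives > 1 h, which is also a limit. Compound 3 `CS(=O)(=O)Nc1ccc2c(c1)S(=O)(=O)N=C(c1c(O)c(-c3cccs3)nn(CC3(C(F)(F)F)CC3)c1=O)N2` gives > 1 h, again a limit. The record so far is therefore (the limit of > 1 h in this assay, at which 3 of the 3 values shown sit), and compound 3 offers no exact starting value.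

Compound 4 `CS(=O)(=O)Nc1ccc2c(c1)S(=O)(=O)N=C(c1c(O)c(-c3cccs3)nn(CC3(C(F)(F)F)CCC3)c1=O)N2` differs from compound 3 in one place: 1-(trifluoromethyl)cyclobutyl in place of 1-(trifluoromethyl)cyclopropyl on a saturated chain carbon bound to an aromatic nitrogen. Here, 1-(trifluoromethyl)cyclobutyl replaces 1-(trifluoromethyl)cyclopropyl on a saturated chain carbon bound to an aromatic nitrogen.

The measured changes at this part of the molecule are a step that the two limits leave unreadable from compound 1 to compound 2, a step that the two limits leave unreadable from compound 1 to compound 3 and a step that the two limits leave unreadable from compound 2 to compound 3. None of them has a readable size, so none shows how far, or in which direction, a change here moves the half-life. Compound 3 keeps its limit reading in a step that the two limits leave unreadable from compound 1 to compound 3, and this is the closest guide available. The expected result is a step that the limit leaves unreadable from compound 3 to compound 4, with no step beyond the usual scatter and no favoured direction. Another limit reading is the most likely report. Compound 4 is estimated at 2 h, with an expected range of 1 h to 4 h.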

Compound 4, half-life: 1 h
Beside the measured number, compound 4's estimate is 2.0-fold (0.30 log units) above it; measured number inside the range.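

In this assay, compound 4 is the only one of the four compounds shown to give a plain number, 1 h, so this position now has one reading that is not a limit. For the compounds shown here, with 1-(trifluoromethyl)cyclobutyl in place of 1-(trifluoromethyl)cyclopropyl on a saturated chain carbon bound to an aromatic nitrogen, the result is a number no higher from compound 3 to compound 4 (the limit leaves the size open), which means the larger ring cannot be said to lengthen the half-life at this place, although the earlier compounds left even the direction of any change here unknown. The other two new steps point the same way, a number no higher from compound 2 to compound 4 (the limit leaves the size open) and a number no higher from compound 1 to compound 4 (the limit leaves the size open), but none of the three has a size that can be read, since each starts from a value that is a limit and not a number: the limit of > 1 h in this assay, at which 3 of the 4 values shown sit.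

Going by these compounds, whether the larger ring shortens the half-life at all, and by how much, stays open, since the true values of the compounds at the limit are unknown. Also open, on these data alone, is how a group carrying an amine or a carboxylic acid, or a longer chain in place of the ring, would read in this assay.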